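The source may hold more compounds than are shown below. What is called first, only, known or untested is meant among the compounds shown, and "the series" means these compounds.

Measured so far:
compound 1 `COc1cc2ncnc(Nc3ccc(F)c(Cl)c3)c2cc1OCCCSc1nc2ccccc2s1` — 5370 nM
compound 2 `COc1cc2ncnc(Nc3ccc(C)cc3)c2cc1OCCCSc1nc2ccccc2s1` — 14300 nM

In a functional assay on MCF7 cells (Homo sapiens) for cytotoxicity, read by MTT assay, with a stated time of 24 h (a higher number here means a weaker inhibitor, a lower number a stronger inhibitor), compound 1 gives the lowest of the two numbers shown; the only neighbour is compound 2, and the step of a 2.7-fold higher number from compound 1 to compound 2 (0.43 log units; beyond the scatter) is modest but beyond the scatter. That step changes the group on the nitrogen on an aromatic ring and leaves the chain untouched.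

Compound 3 `CCCCc1nc(Cl)c(C=O)n1CCCOc1cc2c(Nc3ccc(F)c(Cl)c3)ncnc2cc1OC` differs from compound 1 at the far end of that chain: 2-butyl-4-chloro-5-formyl-1H-imidazol-1-yl in place of (1,3-benzothiazol-2-yl)sulfanyl on a saturated chain carbon, three bonds along the chain from an oxygen on an aromatic ring. Among the measured compounds shown here, no measured step touches this position, so nothing in the data says which way the number should move or by how much. For the measured compounds named here, the one step known, from compound 1 to compound 2, concerns a different part of the shared core and does not bear on this exchange.

Compound 3 is therefore expected to stay near compound 1 in this assay, with a wide band around that: estimate 6000 nM, between 1500 nM and 25000 nM, a step of a 1.1-fold higher number from compound 1 to compound 3 (0.05 log units; within the scatter).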

Compound 3, half-maximal inhibitory concentration: 5020 nM
Estimate against measurement, compound 3: 1.2-fold (0.08 log units) above, and the stated range covers the measured number.
By their numbers in this assay, from the lowest: compounds 3 and 1 (each within the scatter of the next); then compound 2.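

In this assay, the far end of the chain now has a step that can be read: placing 2-butyl-4-chloro-5-formyl-1H-imidazol-1-yl where (1,3-benzothiazol-2-yl)sulfanyl stood gives a 1.1-fold lower number from compound 1 to compound 3 (0.03 log units; within the scatter). The two end groups differ in ring count and atoms, yet with the 3-chloro-4-fluorophenyl group held fixed, this assay does not separate them, while the change on the nitrogen gives a 2.7-fold higher number from compound 1 to compound 2 (0.43 log units; beyond the scatter). No independent measurement bears on this result, so it remains unexplained.

The compounds shown leave open whether the number would hold with an amine such as morpholine or with a carboxylic acid at the chain end, or with a longer chain. They also leave open whether 2-butyl-4-chloro-5-formyl-1H-imidazol-1-yl would give the same result alongside the 4-methylphenyl group.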